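The source may hold more compounds than are shown below. What is called first, only, known or untested is meant among the compounds shown, and "the series" means these compounds.

In a functional assay on HeLa cells (Homo sapiens) for antiproliferative activity, read by MTT assay, with a stated time of 48 h (a lower number here means a stronger inhibitor, a higher number a weaker inhibitor), three compounds have been measured so far: compound 1 `Cc1ccc2nc(NC(c3cn(-c4ccccc4)nc3-c3cccc([N+](=O)[O-])c3)c3c(O)ccc4ccccc34)sc2c1` gives 7360 nM, compound 2 `Oc1ccc2ccccc2c1C(Nc1nc2ccccc2s1)c1cn(-c2ccccc2)nc1-c1ccccc1` gives 17300 nM, and compound 3 `COc1cccc(-c2nn(-c3ccccc3)cc2C(Nc2nc3ccccc3s2)c2c(O)ccc3ccccc23)c1` gives 14900 nM. Compound 3 lies within the scatter of compound 2, and its number is higher than that of compound 1 by a gap just beyond the scatter.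

Compound 4 `COc1ccc(-c2nn(-c3ccccc3)cc2C(Nc2nc3ccccc3s2)c2c(O)ccc3ccccc23)cc1` is an isomer of compound 3, with the same atoms joined differently: 4-methoxyphenyl in place of 3-methoxyphenyl on an aromatic carbon. The change sits on an aromatic carbon of a five-membered aromatic ring with 2 nitrogen.

Going by the values given here, only one measured step bears on this change, the introduction of methoxy in place of hydrogen on an aromatic carbon: a 1.2-fold lower number from compound 2 to compound 3 (0.06 log units; within the scatter), within the scatter. Among the compounds with values here, no measured pair compares two methoxy placements directly, so this evidence is indirect. No step beyond the scatter is therefore expected in this assay.

The expected step is a 1.1-fold lower number from compound 3 to compound 4 (0.06 log units; within the scatter). Compound 4 is estimated at 13000 nM, with an expected range of 6000 nM to 28000 nM.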

Compound 4, half-maximal inhibitory concentration: 9340 nM
Estimate against measurement, compound 4: 1.4-fold (0.14 log units) above; measured number inside the range.
By their numbers in this assay, from the lowest: compounds 1, 4, 3 and 2 (each within the scatter of the next, the first and the last beyond it).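

Going by these compounds alone, exchanging 3-methoxyphenyl for 4-methoxyphenyl on the aromatic carbon of the five-membered ring gives a 1.6-fold lower number from compound 3 to compound 4 (0.20 log units; within the scatter) and is the first direct comparison of two methoxy placements; in this assay the two placements are not told apart. Methoxy in place of hydrogen in the 4-methoxyphenyl form gives a 1.9-fold lower number from compound 2 to compound 4 (0.27 log units; within the scatter) and also stays within the scatter, so neither placement separates from the unsubstituted phenyl of compound 2, although this step is the larger of the two methoxy-for-hydrogen steps in printed size. No measurement shown here accounts for these small differences.

Still open, going by these compounds, is whether an amine or a carboxylic acid in place of methoxy on this phenyl ring would move the number beyond the scatter. On these data alone, a longer alkoxy chain in place of methoxy remains equally open.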